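A few compounds are considered here, and "the series" means these few. Any claim that something is new, unique, unknown or untested is made for them only; others in the source may bear on it.

Measured compounds:

Compound 1, `CC(=O)c1nn(-c2ccccc2)/c(=N/c2nc(-c3c(C)n(C)n(-c4ccccc4)c3=O)cs2)s1`: in a functional assay on MCF7 cells (Homo sapiens) for cytotoxicity, read by sulforhodamine B assay, with a stated time of 72 h (a lower number here means a stronger inhibitor, a higher number a weaker inhibitor), compound 1 gives > 100000 nM, which is a limit of the assay rather than a number.

Compound 2, `CC(=O)c1nn(-c2ccc([N+](=O)[O-])cc2)/c(=N/c2nc(-c3c(C)n(C)n(-c4ccccc4)c3=O)cs2)s1`: in this assay compound 2 gives > 100000 nM, again a limit of the assay.

Compound 3, `Cc1c(-c2csc(/N=C3\S/C(=C\c4ccccc4)C(=O)N3c3ccccc3)n2)c(=O)n(-c2ccccc2)n1C`: in this assay compound 3 gives > 100000 nM, also a limit of the assay.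

Compound 3 therefore stands where every measured value stands: at the edge of what this assay can report, with no number to compare. Going by the values given here, the one measured step, a step that the two limits leave unreadable from compound 1 to compound 2, cannot be read in size, since both of its compounds sit at the limit; this is the situation described by the limit of > 100000 nM in this assay, at which 3 of the 3 values shown sit.

Compound 4, `Cc1c(-c2csc(/N=C3\S/C(=C\c4ccc(Cl)cc4)C(=O)N3c3ccccc3)n2)c(=O)n(-c2ccccc2)n1C`, differs from compound 3 in one place: chloro in place of hydrogen on an aromatic carbon. Among the compounds with values here, no measured step concerns this change, and the only step that exists at all is unreadable. The expectation for compound 4 in this assay therefore rests on the three limits alone: compound 4 is expected to stay at or near the limit, so the step that the limit leaves unreadable from compound 3 to compound 4 is expected to be none beyond the scatter. The estimate for compound 4 in this assay is 150000 nM, with a range from 30000 nM to 1000000 nM, and a limit rather than a number is the most likely report.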

Compound 4, half-maximal inhibitory concentration: > 100000 nM
Compound 4: only a limit was reported; the forecaster's own chance of this, stated with the estimate: 80%; the middle value is on the limit's open side.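

Compound 4 gives > 100000 nM in this assay, which is a limit and not a number. Compound 3 also sits at a limit, so no step from compound 3 to compound 4 can be read: the limit of > 100000 nM in this assay, at which 4 of the 4 values shown sit.

The compounds shown leave open whether any close relative gives a true number in this assay, and whether chloro in place of hydrogen would then change it.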